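The source may report more compounds than this note shows. Statements on the series, on what has been measured and on what is new or still open speak of the compounds shown alone.

Working notes on the oxime-ether series. In a functional assay on MKN-45 cells (Homo sapiens) for antiproliferative activity, tested at 1 uM (on this read-out lower numbers stand for less inhibition and higher numbers for more inhibition at the one concentration tested (going by the name of the read-out)), compound 1 `COc1ccc(CO/N=C/c2c(C)nn(C)c2Oc2ccc(Cl)cc2)cc1` gives 28.1%, the highest of the three numbers in hand. Compound 3 `Cc1nn(-c2ccccc2)c(Oc2ccc(Cl)cc2)c1/C=N/OCc1ccc(C(=O)OC(C)(C)C)cc1` gives -9.9% and compound 2 `Cc1c(CO/N=C/c2c(-c3ccccc3)nn(-c3ccccc3)c2Oc2ccc(Cl)cc2)cccc1-c1ccccc1` gives -15%; both lie beyond the scatter below compound 1. Among the measured compounds shown here, no pair of measured compounds differs in only one place, so no single step has been measured. Compound 4 `CCOC(=O)c1ccc(CO/N=C/c2c(C)nn(C)c2Oc2ccc(Cl)cc2)cc1` is the next structure to be run: compared with compound 1 it shows (ethoxycarbonyl in place of methoxy on an aromatic carbon). For the measured compounds named here, with no directly comparable step available, the change is expected to cost some inhibition, though not beyond doubt, so for compound 4 in this assay the estimate is 15% (range -10% to 40%), an expected step of a number 13.1 percentage points lower from compound 1 to compound 4 (beyond the scatter).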

Compound 4, a percentage reported as inhibition, at one concentration (the size of the read-out at that concentration, not a potency): 20.9%
For compound 4 the middle estimate is 5.9 percentage points below the measured one, and the stated range covers the measured number.
By their numbers in this assay, from the lowest: compounds 2 and 3 (each within the scatter of the next); then compounds 4 and 1 (each within the scatter of the next).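

In this assay, among the compounds shown here, the only single step measured so far, ethoxycarbonyl in place of methoxy on an aromatic carbon para to a large group, gives a number 7.2 percentage points lower from compound 1 to compound 4 (within the scatter) and so shows that this position accepts the larger group of the two without a change beyond the scatter. Nothing in hand bears on why the step has this size. Going by these compounds, whether an amine, a carboxylic acid or a longer chain at this position would hold the number remains open, as does whether this step carries over to other cores.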